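This account rests on a few compounds, and the source may have more. Where it says the series, first, only, none or still open, it means among the compounds named here.

In an assay on RBL-1 cells for inhibition of Polyunsaturated fatty acid 5-lipoxygenase (Rattus norvegicus) (on this read-out higher numbers stand for weaker inhibition and lower numbers for stronger inhibition), compound 1 `O=C(/C=C/c1ccc(O)c(O)c1)c1ccc(O)cc1` gives 4 nM. Compound 2 `COc1ccccc1C(=O)/C=C/c1ccc(O)c(O)c1` gives 27 nM, and compound 3 `COc1ccc(C(=O)/C=C/c2ccc(O)c(O)c2)cc1` gives 20 nM. Among these three numbers compound 3 stands second highest: its value and that of compound 2 lie within the scatter of each other, while the step of a 5.0-fold higher number from compound 1 to compound 3 (0.70 log units; beyond the scatter) lies beyond it. Compound 4 `COc1ccc(C(=O)/C=C/c2ccc(O)c(O)c2)c(OC)c1` differs from compound 3 by methoxy in place of hydrogen on an aromatic carbon. Among the measured compounds shown here, the only measured step that bears on this change is the one in which a methyl replaced hydrogen on an oxygen on an aromatic ring, giving a 5.0-fold higher number from compound 1 to compound 3 (0.70 log units; beyond the scatter). Placing a second methoxy on a ring that already bears one has no direct precedent among these compounds, so the expected step of a 1.5-fold higher number from compound 3 to compound 4 (0.18 log units; within the scatter) is small, a slight rise if anything, with little reason to expect a move beyond the scatter. Compound 4 is therefore estimated at 30 nM, within a range from 12 nM to 75 nM.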

Compound 4, half-maximal inhibitory concentration: 10 nM
Estimate against measurement, compound 4: 3.0-fold (0.48 log units) above; the whole stated range lies above it.
By their numbers in this assay, from the lowest: compound 1; then compounds 4, 3 and 2 (each within the scatter of the next, the first and the last beyond it).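

Putting methoxy on the aromatic carbon ortho to a large group and meta to a methoxy group gives a 2.0-fold lower number from compound 3 to compound 4 (0.30 log units; within the scatter) in this assay, so this ring carries a second methoxy with no change that stands out from the scatter. The same kind of change read from the other side gives a 2.7-fold lower number from compound 2 to compound 4 (0.43 log units; beyond the scatter) and does lie beyond the scatter, so in this pair, adding a methoxy to a ring that already bears one goes with stronger inhibition rather than weaker. Nothing measured here accounts for either step.

Still open, on these data alone, is whether this carbon would tolerate something other than methoxy, such as an amine, a carboxylic acid or a longer chain like ethoxy. Also open, as far as these compounds go, is whether the same change would behave alike on a ring bearing hydroxy groups instead of methoxy groups.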